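Chain swap on the nitroimidazole: compound 2 to compound 3

The source may report more compounds than this note shows. Statements on the series, on what has been measured and on what is new or still open speak of the compounds shown alone.

In a functional assay on HT-29 cells (Homo sapiens) for inhibition, read by sulforhodamine B assay, with a stated time of 72 h (a lower number here means a stronger inhibitor, a higher number a weaker inhibitor), compound 1 `COc1cc2c(Nc3ccc(OCc4cccc(F)c4)c(Cl)c3)ncnc2cc1OCCCn1ccnc1[N+](=O)[O-]` gives 940 nM. Compound 2 `COc1cc2c(Nc3ccc(OCc4cccc(F)c4)c(Cl)c3)ncnc2cc1OCCCCCCn1ccnc1[N+](=O)[O-]` gives > 50000 nM, which is a limit of the assay and not a number. Compound 3 `COc1cc2c(Nc3ccc(OCc4cccc(F)c4)c(Cl)c3)ncnc2cc1OCCOCCn1ccnc1[N+](=O)[O-]` keeps the shared core and changes only the chain: 2-(2-nitro-1H-imidazol-1-yl)ethoxy in place of 4-(2-nitro-1H-imidazol-1-yl)butyl, on a saturated chain carbon, two bonds along the chain from an oxygen on an aromatic ring (2-(2-nitro-1H-imidazol-1-yl)ethoxy in place of 4-(2-nitro-1H-imidazol-1-yl)butyl on a saturated chain carbon, two bonds along the chain from an oxygen on an aromatic ring).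

Among the compounds with values here, one measured step bears on this change: an at least 53-fold higher number from compound 1 to compound 2 (1.72 log units; beyond the scatter). It is large, beyond the scatter, and shows that in this pair a chain change alone can carry a big shift in this assay. Compound 3 is expected to recover part, but not all, of that loss. The expected step, toward a lower number, is an at least 8.3-fold lower number from compound 2 to compound 3 (0.92 log units; beyond the scatter). For compound 3 the estimate is 6000 nM, with an expected range of 1500 nM to 40000 nM.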

Compound 3, half-maximal inhibitory concentration: 2590 nM
Compound 3: middle estimate off by 2.3-fold (0.36 log units), on the high side; the measured number falls inside the stated range.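

In this assay, within the data shown here, 2-(2-nitro-1H-imidazol-1-yl)ethoxy in place of 4-(2-nitro-1H-imidazol-1-yl)butyl gives an at least 19-fold lower number from compound 2 to compound 3 (1.28 log units; beyond the scatter), so the loss seen with the long chain at this position is not fixed for every chain beyond the one in compound 1. Going by these compounds, compound 2 stands at a limit of the assay and not at a number, so the true size of this step stays unknown: the limit of > 50000 nM in this assay, at which 1 of the 3 values shown sits. The recovery is incomplete, with a 2.8-fold higher number from compound 1 to compound 3 (0.44 log units; beyond the scatter), so compound 3 does not return to the level of compound 1 in this assay.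

The compounds shown do not separate the oxygen in the chain from the length of the chain as the source of the step. A pentyl chain, or an amine in place of that oxygen, would bear on this.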